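Nitro for bromo on the diaryl ether series

The compounds below may be only part of what the source reports. "The series", "measured", "known", "first", "only" and "open" are said of these compounds alone.

Among the measured compounds shown here, compound 3 `S=C(N/N=C/c1ccc(Oc2ccc(Br)cc2)cc1)Nc1ccc(Cl)cc1` gives 6.37 in a physicochemical assay for lipophilicity, in phosphate buffer, measured as octanol-water partition, with a stated time of 24 h (a lower number here means a more polar compound, a higher number a more lipophilic compound), the highest of the three numbers so far: compound 1 `Cc1ccc(Oc2ccc(/C=N/NC(=S)Nc3ccc(Cl)cc3)cc2)cc1` gives 5.97, and compound 2 `O=[N+]([O-])c1ccc(Oc2ccc(/C=N/NC(=S)Nc3ccccc3)cc2)cc1` gives 4.95. For the measured compounds named here, the only single-point step measured, a number 0.40 log units higher from compound 1 to compound 3 (beyond the scatter), concerns a different exchange and does not bear directly on the change at hand. Compound 4 `O=[N+]([O-])c1ccc(Oc2ccc(/C=N/NC(=S)Nc3ccc(Cl)cc3)cc2)cc1` takes the step (nitro in place of bromo on an aromatic carbon). Going by the values given here, no measured pair isolates this exchange. Compound 2, which carries the nitro group, stands lowest, and compound 3, which carries the bromo group, stands highest. A drop from compound 3 is therefore expected, estimated at a number 0.87 log units lower from compound 3 to compound 4 (beyond the scatter). Compound 4 is expected at 5.5, with a range of 5 to 6.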

Compound 4, partition coefficient: 5.52
Beside the measured number, compound 4's estimate is 0.02 log units below it; low and high end bracket the measured number.
By their numbers in this assay, from the lowest: compound 2; then compound 4; then compound 1; then compound 3.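

In this assay nitro in place of bromo gives a number 0.85 log units lower from compound 3 to compound 4 (beyond the scatter) and nitro in place of methyl gives a number 0.45 log units lower from compound 1 to compound 4 (beyond the scatter) so with the chloro group held constant, nitro stands lowest of the three groups at this position. A second exchange can now be read, as chloro in place of hydrogen gives a number 0.57 log units higher from compound 2 to compound 4 (beyond the scatter) on the nitro side of the series. No measurement at hand accounts for these steps. Going by these compounds, whether the order of nitro, methyl and bromo holds without the chloro group remains open, as does where an amine or a carboxylic acid would fall at this position.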